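From hydroxyamino to methoxy on a carbonyl carbon

The source may report more compounds than this note shows. Statements on the series, on what has been measured and on what is new or still open speak of the compounds shown alone.

In a functional assay on MOLT-4 cells (Homo sapiens) (a lower number here means a stronger inhibitor, a higher number a weaker inhibitor), compound 1 (`COc1cc(NC(C)CCCNC(=O)NCCO)c2ncccc2c1`) gives > 100000 nM, which is a limit and not a number. Compound 2 (`COc1cc(NC(C)CCCNC(=O)NCCCCCO)c2ncccc2c1`) gives 61000 nM. Compound 3 (`COc1cc(NC(C)CCCNC(=O)NO)c2ncccc2c1`) gives > 100000 nM, which is also only a limit. Compound 4 (`COC(=O)NCCCC(C)Nc1cc(OC)cc2cccnc12`) carries methoxy in place of hydroxyamino on a carbonyl carbon. The nearest measured changes give little guidance: an at least 1.6-fold lower number from compound 1 to compound 2 (0.21 log units; that floor lies within the scatter) and an at least 1.6-fold higher number from compound 2 to compound 3 (0.21 log units; that floor lies within the scatter) have floors within the scatter, while a step that the two limits leave unreadable from compound 1 to compound 3 cannot be read. In this assay, the expected step is therefore none beyond the scatter, in either direction (an at least 1.1-fold lower number from compound 3 to compound 4 (0.04 log units; that floor lies within the scatter)). For compound 4 the estimate is 90000 nM, with an expected range of 40000 nM to 200000 nM.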

Compound 4, half-maximal inhibitory concentration: > 100000 nM
Compound 4: no number, only a limit (the forecaster's own chance of this, stated with the estimate: 60%); middle value at least 1.1-fold (0.04 log units) away from the limit.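

In this assay, going by these compounds alone, methoxy on this carbonyl carbon, which has no hydrogen-bond donors, gives no measurable number, just as hydroxyamino did, so compound 2 remains the only compound here with a number rather than a limit. Within the data shown here, the steps to compound 4 from compound 3 and from compound 1 cannot be read, and the one readable step is an at least 1.6-fold higher number from compound 2 to compound 4 (0.21 log units; that floor lies within the scatter). These results therefore separate the groups poorly: the limit of > 100000 nM in this assay, at which 3 of the 4 values shown sit.

Still open, on these data alone, is whether a longer chain ending in an amine or a carboxylic acid on this carbonyl carbon would give a number clearly under that limit.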